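Enone series: aryl for alkyl on the chain

The compounds below may be only part of what the source reports. "The series", "measured", "known", "first", "only" and "open" are said of these compounds alone.

Compound 3 `CCC(/C=C(\COC(C)=O)C(=O)c1ccccc1)CC` gives 50000 nM in a functional assay on HeLa cells (Homo sapiens) for inhibition, read by sulforhodamine B assay, with a stated time of 48 h (on this read-out higher numbers stand for weaker inhibition of growth and lower numbers for stronger inhibition of growth), the highest of the three numbers recorded so far. Compound 2 `O=C(/C(=C/C1CCCCC1)CCl)c1ccccc1` gives 30000 nM in this assay, which lies within the scatter of compound 3. Compound 1 `O=C(/C=C/c1ccc(Cl)cc1Cl)c1ccccc1` gives 18000 nM in this assay, beyond the scatter from compound 3 and the lowest number of the three. Compound 1 carries an aromatic ring on the chain where compounds 2 and 3 carry saturated groups; three compounds are too few to call this a pattern.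

Compound 4 `CC(=O)OC/C(=C\c1ccccc1Br)C(=O)c1ccccc1` differs from compound 3 by 2-bromophenyl in place of pentan-3-yl on a double-bonded chain carbon bound to a double-bonded chain carbon. Among the measured compounds shown here, no step between measured compounds matches this change, so its size has to be guessed. A step toward a lower number in this assay of modest size, just beyond the scatter, is expected because compound 1 with an aromatic ring on the chain gives 18000 nM. The expected step from compound 3 to compound 4 is a 2.5-fold lower number from compound 3 to compound 4 (0.40 log units; beyond the scatter). Compound 4 is therefore expected at 20000 nM in this assay, with a range from 8000 nM to 50000 nM.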

Compound 4, concentration for 50% growth inhibition: 20000 nM
Compound 4: middle estimate and measured number agree at the digits printed, within the range that was stated.
By their numbers in this assay, from the lowest: compounds 1, 4, 2 and 3 (each within the scatter of the next, the first and the last beyond it).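

Among the compounds shown here, on the shared core, compounds 3 and 4 give the only comparison so far that differs in one place: 2-bromophenyl in place of pentan-3-yl on a double-bonded chain carbon bound to a double-bonded chain carbon. In this assay this change reads as a 2.5-fold lower number from compound 3 to compound 4 (0.40 log units; beyond the scatter), so at this position, in this one pair, the group with a six-membered aromatic ring goes with stronger inhibition of growth than the open saturated group, something compounds 1, 2 and 3 could not show, as they differ from one another in more than one place. Nothing measured here bears on the origin of this step.

A single pair does not separate the contribution of the aromatic ring from that of the bromine, so an unsubstituted phenyl, a pyridine ring or a longer alkyl chain at the same position would each leave a different reading. Also open, going by these compounds, is whether the step carries over to the core of compound 2, with its chloromethyl group, or holds only on the core shared by compounds 3 and 4.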